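Alkyl change on the oxadiazole of compound 2

A few compounds are considered here, and "the series" means these few. Any claim that something is new, unique, unknown or untested is made for them only; others in the source may bear on it.

Compound 1 `CCN(CC)S(=O)(=O)c1ccc(S(=O)(=O)N2CCC[C@@H](C(=O)NC3CN(C(=O)C4CC4)C3)C2)cc1` gives 2800 nM in a functional assay on MIA PaCa-2 cells (Homo sapiens) for inhibition, read by MTT assay, with a stated time of 7 days; on this read-out higher numbers stand for weaker inhibition and lower numbers for stronger inhibition. Compound 2 `CCN(CC)S(=O)(=O)c1ccc(S(=O)(=O)N2CCC[C@@H](C(=O)N3CCN(c4nc(C)no4)CC3)C2)cc1` gives 250 nM. Compound 3 `CCN(CC)C(=O)[C@@H]1CCCN(S(=O)(=O)c2ccc(S(=O)(=O)N(CC)CC)cc2)C1` gives 6400 nM.

Compound 2 holds the lowest number of the three. From compound 1 the step is an 11-fold lower number from compound 1 to compound 2 (1.05 log units; beyond the scatter), and from compound 3 it is a 26-fold higher number from compound 2 to compound 3 (1.41 log units; beyond the scatter); both steps lie beyond the scatter, so compound 2 is the strongest inhibitor among the measured compounds.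

Compound 4 `CCN(CC)S(=O)(=O)c1ccc(S(=O)(=O)N2CCC[C@@H](C(=O)N3CCN(c4nc(C(C)C)no4)CC3)C2)cc1` differs from compound 2 in one place: isopropyl in place of methyl on an aromatic carbon. For the measured compounds named here, none of the measured steps touches this position; an 11-fold lower number from compound 1 to compound 2 (1.05 log units; beyond the scatter), a 2.3-fold higher number from compound 1 to compound 3 (0.36 log units; beyond the scatter) and a 26-fold higher number from compound 2 to compound 3 (1.41 log units; beyond the scatter) all concern the group on the carbonyl carbon, while the oxadiazole ring is untouched in each. Going by the values given here, the data therefore give no step to borrow for the change from methyl to isopropyl. With no guide, the expected step from compound 2 to compound 4 is no change at the digits printed from compound 2 to compound 4 (within the scatter), within the scatter. Compound 4 is estimated at 250 nM, with a range of 100 nM to 700 nM.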

Compound 4, half-maximal inhibitory concentration: 50 nM
The estimate for compound 4 lay 5.0-fold (0.70 log units) above the measured number; measured number outside the range, below it.
By their numbers in this assay, from the lowest: compound 4; then compound 2; then compound 1; then compound 3.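

On the aromatic carbon between two ring nitrogen atoms, the alkyl group alone moves the read-out: in this assay, isopropyl in place of methyl gives a 5.0-fold lower number from compound 2 to compound 4 (0.70 log units; beyond the scatter). The earlier steps shown here all concerned the group on the carbonyl carbon, whereas this one shows that the oxadiazole substituent also affects inhibition, and that with the carbonyl side held constant, isopropyl gives stronger inhibition than methyl. Nothing given here bears on the reason for this step.

The two alkyl groups do not show whether the trend continues to a tert-butyl group or a longer chain such as n-butyl, or how a cyclopropyl ring, an amine or a carboxylic acid at this carbon would read. On these data alone, whether isopropyl would give a similar step with a different group on the carbonyl carbon also remains open.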